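Short-linker amide change from compound 1 to compound 4

The source may report more compounds than this note shows. Statements on the series, on what has been measured and on what is new or still open speak of the compounds shown alone.

Measured compounds:
compound 1 `CN(C(=O)CSc1nnc(Cc2nn(C)c(=O)c3ccccc23)n1C)c1ccc(Cl)cc1Cl`: > 30000 nM
compound 2 `CC(C)Oc1ccc(NC(=O)CCCCCCCSc2nnc(Cc3nn(C)c(=O)c4ccccc34)n2C)cc1`: 1100 nM
compound 3 `Cn1c(Cc2nn(C)c(=O)c3ccccc23)nnc1SCCCCCCCCCC(=O)Nc1ccc(Cl)cc1Cl`: 2300 nM

In an assay on isolated protein (Mus musculus) for inhibition of IL15-IL15 receptor (Homo sapiens), read by resazurin assay, with stated times of 30 min and 2.5 days (a lower number here means a stronger inhibitor, a higher number a weaker inhibitor), compound 1 gives > 30000 nM, which is a limit of the assay and not a number. Compound 1 therefore stands at the limit of > 30000 nM in this assay, at which 1 of the 3 values shown sits. Compound 2 gives 1100 nM and compound 3 gives 2300 nM, and these two values lie within the scatter of each other; both carry the long saturated chain between the thioether and the amide carbonyl, whereas compound 1 carries the short one.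

Compound 4 `Cn1c(Cc2nn(C)c(=O)c3ccccc23)nnc1SCC(=O)Nc1ccc(I)cc1` keeps the short chain of compound 1 and differs from it by (4-iodophenyl)amino in place of (2,4-dichlorophenyl)(methyl)amino on a carbonyl carbon. Among the compounds with values here, no measured pair covers this change, so its size is not known from the data. Because compound 1 sits at the limit of > 30000 nM in this assay, at which 1 of the 3 values shown sits, the step from compound 1 to compound 4 is expected to be small, an at least 1.5-fold lower number from compound 1 to compound 4 (0.17 log units; that floor lies within the scatter), with a fair chance that compound 4 again returns only a limit. Compound 4 is estimated at 20000 nM, in the range 5000 nM to 60000 nM.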

Compound 4, half-maximal inhibitory concentration: "not active" (no number reported)
For compound 4 the study gives words and no number; no gap can be computed for the estimate.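

Within the data shown here, compound 4 is reported only in words, as not active, with no number, and no step from compound 1 to compound 4 can be read. The compounds shown leave open how chain length alone, with the amide group held fixed, bears on inhibition.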